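Swapping Thiomorpholin-4-yl for Morpholin-4-yl on a Thiocarbonyl Carbon

The compounds below may be only part of what the source reports. "The series", "measured", "known", "first", "only" and "open" are said of these compounds alone.

Measured compounds:
compound 1 `Cc1cccc(/C(N)=N/NC(=S)N2CCSCC2)n1`: 67.6%
compound 2 `Cc1cccc(/C(N)=N/NC(=S)N2CCOCC2)n1`: 85.4%
compound 3 `N/C(=N\NC(=S)N1CCSCC1)c1ccc(F)cn1`: 70.5%

Three compounds were tested in a functional assay on HeLa cells (Homo sapiens) for cytotoxicity, read by MTT assay, with a stated time of 72 h, tested at 10 uM; a higher number here means more inhibition of growth at the concentration tested, a lower number less inhibition of growth. Compound 1 gives 67.6%, and compound 2, which carries morpholin-4-yl in place of thiomorpholin-4-yl on a thiocarbonyl carbon, gives 85.4%. Among the measured compounds shown here, that step, a number 17.8 percentage points higher from compound 1 to compound 2 (beyond the scatter), is the only measured instance of this change. Compound 3 gives 70.5%; the difference between its core and the core of compound 1 is not broken down here. The values of compound 3 and compound 1 lie within the scatter of each other, so no order between them is claimed.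

Compound 4 `N/C(=N\NC(=S)N1CCOCC1)c1ccc(F)cn1` has not yet been measured. It differs from compound 3 by morpholin-4-yl in place of thiomorpholin-4-yl on a thiocarbonyl carbon, the same kind of change as from compound 1 to compound 2. Because the measured step of a number 17.8 percentage points higher from compound 1 to compound 2 (beyond the scatter) was upward in this assay, a step of about a number 14.5 percentage points higher from compound 3 to compound 4 (beyond the scatter) is expected from compound 3 to compound 4, resting on that single pair. Compound 4 is therefore estimated at 85%, with a likely range from 72% to 96%.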

Compound 4, percent growth inhibition at one concentration: 81.9%
For compound 4 the middle estimate is 3.1 percentage points above the measured one; measured number inside the range.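

In this assay, morpholin-4-yl in place of thiomorpholin-4-yl on a thiocarbonyl carbon again raises the number on the second core, with a number 11.4 percentage points higher from compound 3 to compound 4 (beyond the scatter) for this pair. The two steps point the same way, and their sizes cannot be told apart: the same change on two cores in this assay, a number 17.8 percentage points higher (beyond the scatter) from compound 1 to compound 2 and a number 11.4 percentage points higher (beyond the scatter) from compound 3 to compound 4, 6.4 percentage points apart, within the scatter of two such steps. Among the compounds shown here, this shows that the change carried over between these two cores, but with only two pairs, each read at a single concentration, it does not show that the change would behave the same way on any other core, and the data do not tell why the number rises.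

The compounds shown leave open how other groups on the thiocarbonyl carbon would compare with these two, for example piperidin-1-yl or a dimethylamino group. As far as these compounds go, it also remains open whether the step would persist on a core carrying chlorine or a methoxy group in place of the fluorine of compound 4.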